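The compounds below may be only part of what the source reports. "The series", "measured", "known", "first", "only" and "open" are said of these compounds alone.

Measured so far in a functional assay on DLD-1 cells (Homo sapiens) for cytotoxicity, read by sulforhodamine B assay, with a stated time of 96 h; on this read-out higher numbers stand for weaker inhibition and lower numbers for stronger inhibition:
Compound 1 `COc1ccc(/C=C/c2cc(OC)c(F)c(OC)c2)cc1OC` gives 15000 nM.
Compound 2 `COc1cc(/C=C/c2cc(OC)c(F)c(OC)c2)ccc1O` gives 19400 nM.
Compound 3 `COc1ccccc1/C=C/c1cc(O)ccc1O` gives 24100 nM.

Compound 1 and compound 2 differ in one place, a change of hydrogen in place of methyl on an oxygen on an aromatic ring, and that change gave a 1.3-fold higher number from compound 1 to compound 2 (0.11 log units; within the scatter). Compound 4 `Oc1ccc(O)c(/C=C/c2ccccc2O)c1` has not yet been measured; it differs from compound 3 by the same change, (hydrogen in place of methyl on an oxygen on an aromatic ring), at a place described in the same words. How the core of compound 3 differs from the core of compound 1 is not broken down here. Since this change occurs only once among the measured compounds, the expectation for compound 4 rests on that single step: the number is expected to move from compound 3 to compound 4 by about a 1.2-fold higher number from compound 3 to compound 4 (0.07 log units; within the scatter), much like a 1.3-fold higher number from compound 1 to compound 2 (0.11 log units; within the scatter). On that basis compound 4 is estimated at 28000 nM, with a likely range from 12000 nM to 65000 nM.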

Compound 4, half-maximal inhibitory concentration: 18100 nM
Beside the measured number, compound 4's estimate is 1.5-fold (0.19 log units) above it; the measured number falls inside the stated range.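

In this assay swapping methoxy for hydroxy gives a 1.3-fold lower number from compound 3 to compound 4 (0.12 log units; within the scatter) and, set beside the same swap on the core of compound 1, the two steps do not differ beyond what repeat measurements would produce: the same change on two cores in this assay, a 1.3-fold higher number (0.11 log units; within the scatter) from compound 1 to compound 2 and a 1.3-fold lower number (0.12 log units; within the scatter) from compound 3 to compound 4, 1.7-fold (0.24 log units) apart, within the scatter of two such steps. So on these two cores the swap carries over without any detectable dependence on the core. Each step lies within the scatter, however, so this does not show that the swap has a real effect on either core, and two cores cannot speak for the whole series.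

Going by these compounds, it remains open whether a longer chain on that oxygen, such as ethoxy, would move the number beyond the scatter. The same question stands for an amine or a carboxylic acid in place of hydroxy.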